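A few compounds are considered here, and "the series" means these few. Any claim that something is new, unique, unknown or untested is made for them only; others in the source may bear on it.

Compound 1 `COc1ccc(Oc2ccc(C(C)C)cc2-c2ccsc2S(=O)(=O)NCCNC(=O)Nc2cc(Cl)cc(Cl)c2)cc1OC` and compound 2 `CC(C)c1ccc(Oc2ccc(O)c(O)c2)c(-c2ccsc2S(=O)(=O)NCCNC(=O)Nc2cc(Cl)cc(Cl)c2)c1` were both tested in a functional assay on HL-60 cells (Homo sapiens) for inhibition, read by CCK-8 assay, with a stated time of 48 h; a higher number here means a weaker inhibitor, a lower number a stronger inhibitor. In this assay compound 1 gives 6500 nM. In this assay compound 2 gives 6500 nM. The two structures differ in one place only: 3,4-dihydroxyphenyl in place of 3,4-dimethoxyphenyl on an oxygen on an aromatic ring. This change made the step of no change at the digits printed from compound 1 to compound 2 (within the scatter).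

Compound 3 `COc1ccc(Oc2ccccc2-c2ccsc2S(=O)(=O)N2CCN(C(=S)Nc3ccc(Cl)cc3)CC2)cc1OC` rests on a different core, and the difference between the core of compound 1 and the core of compound 3 is not broken down here. In this assay compound 3 reaches only > 50000 nM, which is a limit of the assay and not a number. Compound 3 therefore stands at the limit of > 50000 nM in this assay, at which 1 of the 3 values shown sits.

Compound 4 `O=S(=O)(c1sccc1-c1ccccc1Oc1ccc(O)c(O)c1)N1CCN(C(=S)Nc2ccc(Cl)cc2)CC1` has not yet been measured. It differs from compound 3 in the same way that compound 2 differs from compound 1: 3,4-dihydroxyphenyl in place of 3,4-dimethoxyphenyl on an oxygen on an aromatic ring. The place of the change is described in the same words for both pairs, so the two changes are the same change on two different cores.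

The step is expected to be a step that the limit leaves unreadable from compound 3 to compound 4, because the same change earlier made no change at the digits printed from compound 1 to compound 2 (within the scatter). Compound 4 is therefore expected to give about 60000 nM in this assay, with a likely range from 20000 nM to 150000 nM, and a real chance that again only a limit is reported.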

Compound 4, half-maximal inhibitory concentration: 5500 nM
The estimate for compound 4 lay 11-fold (1.04 log units) above the measured number, and the stated range ends above it.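

Replacing 3,4-dimethoxyphenyl with 3,4-dihydroxyphenyl in this assay produced an at least 9.0-fold lower number from compound 3 to compound 4 (0.95 log units; beyond the scatter), so on this second core the swap did make a difference. This means the result of the change did not carry over unchanged from the core of compound 1 to the core of compound 3, and a step measured on one core was a poor guide to the step on the other: the same change on two cores in this assay, no change at the digits printed (within the scatter) from compound 1 to compound 2 and an at least 9.0-fold lower number (0.95 log units; beyond the scatter) from compound 3 to compound 4, at least 9.0-fold (0.95 log units) apart, beyond the scatter of two such steps. In this assay, on these data alone, compound 3 gives > 50000 nM, which is a limit of the assay and not a number, so the full size of the step remains unknown, and two pairs show only that the outcome can depend on the core, not why it does or how often: the limit of > 50000 nM in this assay, at which 1 of the 4 values shown sits.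

The two cores differ in more than one place, and the compounds shown do not reveal which of those differences matters for the outcome of this change. As far as these compounds go, it also remains open how other groups on the same oxygen would behave on each core, such as a phenyl ring carrying a single hydroxyl, an amine or a carboxylic acid.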